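Amide replacement of the ring-nitrogen substituent in the sulfoxide series

The compounds below may be only part of what the source reports. "The series", "measured", "known", "first", "only" and "open" are said of these compounds alone.

Measured so far:
compound 1 `[O-][S+](CCNC1CCN(Cc2ccc(F)cc2)CC1)C(c1ccc(F)cc1)c1ccc(F)cc1` — 50.6 nM
compound 2 `[O-][S+](CCNC1CCN(CC(O)Cc2ccccc2)CC1)C(c1ccc(F)cc1)c1ccc(F)cc1` — 91.8 nM
compound 3 `CC(C)(C)CN1CCC(NCC[S+]([O-])C(c2ccc(F)cc2)c2ccc(F)cc2)CC1` — 431 nM

In an assay on membranes from striatum (strain Sprague-Dawley) for displacement of a labelled ligand from sodium-dependent dopamine transporter (Rattus norvegicus), read by scintillation counting, with a stated time of 120 min (a lower number here means a stronger inhibitor, a higher number a weaker inhibitor), compound 3 gives the highest number of the three. Its steps to the other two are both beyond the scatter: an 8.5-fold higher number from compound 1 to compound 3 (0.93 log units; beyond the scatter) and a 4.7-fold higher number from compound 2 to compound 3 (0.67 log units; beyond the scatter). Compound 1 and compound 2 differ from each other only within the scatter, a 1.8-fold higher number from compound 1 to compound 2 (0.26 log units; within the scatter).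

Compound 4 `O=C(c1ccc(F)cc1F)N1CCC(NCC[S+]([O-])C(c2ccc(F)cc2)c2ccc(F)cc2)CC1` is not yet measured. It differs from compound 3 as follows: (2,4-difluorophenyl)carbonyl in place of neopentyl on an amine nitrogen in a ring. The group that enters carries a six-membered aromatic ring, as do the groups present in compound 1 and compound 2, whereas the neopentyl of compound 3 has no ring. The two steps that bear on this change are those in which the aromatic-bearing groups of compound 1 and compound 2 were exchanged for the tert-butyl-bearing chain of compound 3, and both ran to a higher number in this assay. Reversing that direction, a lower number is expected for compound 4. Among the measured compounds shown here, the carbonyl that enters has no counterpart among the measured compounds, so the expected step is kept modest and the range wide: a 3.3-fold lower number from compound 3 to compound 4 (0.52 log units; beyond the scatter). Compound 4 is estimated at 130 nM, between 35 nM and 500 nM.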

Compound 4, inhibition constant: 564 nM
For compound 4 the middle estimate is 4.3-fold (0.64 log units) below the measured one; the whole stated range lies below it.
By their numbers in this assay, from the lowest: compounds 1 and 2 (each within the scatter of the next); then compounds 3 and 4 (each within the scatter of the next).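

In this assay, (2,4-difluorophenyl)carbonyl on the amine nitrogen in the ring performs no differently from neopentyl (a 1.3-fold higher number from compound 3 to compound 4 (0.12 log units; within the scatter)), so a six-membered aromatic ring at this position does not by itself separate compound 4 from the ringless compound 3. The same exchange made against the ring-bearing groups of the other two compounds gives clear steps (a 6.1-fold higher number from compound 2 to compound 4 (0.79 log units; beyond the scatter); an 11-fold higher number from compound 1 to compound 4 (1.05 log units; beyond the scatter)), with the larger one against 4-fluorobenzyl. At this position, then, the presence of the aromatic ring matters less than the way it is attached: in compound 1 and compound 2 it is carried on a saturated chain, and in compound 4 on a carbonyl, although the fluorine pattern on the ring changes in the same step.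

The link and the ring substitution remain unseparated here; a plain benzoyl group and a (2,4-difluorophenyl)methyl group on the same nitrogen would tell them apart, and a longer chain between carbonyl and ring would test the spacing. The compounds shown come with no other measurement that could explain these steps.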